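The compounds below may be only part of what the source reports. "The series", "measured", "known", "first", "only" and "open" are said of these compounds alone.

Within the data shown here, compound 1 `COC(=O)c1ccc2ccc(C(=O)c3ccccc3)c-2cc1` is one of three compounds measured in an assay on cells for displacement of a labelled ligand from Orexin/Hypocretin receptor type 1 (Homo sapiens), read by scintillation counting, with stated times of 10 min and 90 min, tested at 10 uM (on this read-out lower numbers stand for less inhibition and higher numbers for more inhibition at the one concentration tested (going by the name of the read-out)), where compound 1 gives 7.2%, the second highest of the three numbers. Its nearest neighbour is compound 3 `NC(=O)c1ccc2ccc(C(=O)c3ccccc3)c-2cc1`, which gives 13.6%; the step between them is a number 6.4 percentage points higher from compound 1 to compound 3 (within the scatter). Compound 2 `COC(=O)c1ccc2ccc(C(=O)c3ccc(C(F)(F)F)cc3)c-2cc1` gives -60.5%, and the step of a number 67.7 percentage points lower from compound 1 to compound 2 (beyond the scatter) is large. Compound 4 `COC(=O)c1ccc2c(C(=O)c3ccccc3)cc(C(=O)c3ccccc3)c-2cc1` differs from compound 1 in one place: benzoyl in place of hydrogen on an aromatic carbon. Among the measured compounds shown here, no measured step adds a benzoyl group, and the only step that adds a group on an aromatic carbon, a number 67.7 percentage points lower from compound 1 to compound 2 (beyond the scatter), involves a different group, so it offers little guidance. The expected step for compound 4 is therefore a number 2.2 percentage points lower from compound 1 to compound 4 (within the scatter), small but with wide uncertainty. Compound 4 is estimated at 5%, between -35% and 30%.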

Compound 4, a percentage reported as inhibition, at one concentration (the size of the read-out at that concentration, not a potency): -10.6%
Compound 4: the middle estimate sits 15.6 percentage points above what was measured; the measured number falls inside the stated range.
By their numbers in this assay, from the lowest: compound 2; then compound 4; then compounds 1 and 3 (each within the scatter of the next).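

In this assay, placing benzoyl on a carbon of the five-membered aromatic ring gives a number 17.8 percentage points lower from compound 1 to compound 4 (beyond the scatter), a change beyond the scatter. Among these compounds, the earlier steps altered the ester or added trifluoromethyl to the benzoyl's ring, so this is the first sign that a substituent on the five-membered ring itself lowers the number. Nothing given here accounts for this step. With benzoyl the only group shown at this position, it remains open whether a methyl group or an amine there would lower the number too.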